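The source may hold more compounds than are shown below. What is called first, only, known or untested is meant among the compounds shown, and "the series" means these compounds.

Of the compounds shown here, three of a shared core have been measured for solubility. Compound 1 `COc1cc(/C=C/C(=O)/C=C(/C=C/c2ccc(O)c(OC)c2)NCCO)ccc1O` gives 11800 nM in a physicochemical assay for solubility, using the shake flask method, in phosphate buffer, with a stated time of 24 h, at pH 6.8; a higher number here means a more soluble compound, a lower number a less soluble compound. Compound 2 `COCCNC(=C\C(=O)/C=C/c1ccc(O)cc1)/C=C/c1ccc(O)cc1` gives 46100 nM in this assay, and compound 3 `COCCNC(=C\C(=O)/C=C/c1ccc(O)c(OC)c1)/C=C/c1ccc(O)c(OC)c1` gives 12700 nM. Compound 2 stands highest of the three: its number is beyond the scatter above both compound 3 and compound 1, so it is the most soluble of the measured set.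

Compound 1 and compound 3 differ in one place only, by hydrogen in place of methyl on an oxygen on a saturated carbon. That change gave a 1.1-fold lower number from compound 3 to compound 1 (0.03 log units; within the scatter), a step that lies within the scatter of repeated measurements, so it cannot be told apart from no change at all.

Compound 4 `O=C(/C=C(/C=C/c1ccc(O)cc1)NCCO)/C=C/c1ccc(O)cc1` has not yet been measured. It differs from compound 2 by hydrogen in place of methyl on an oxygen on a saturated carbon, the same change in the same place, on an oxygen on a saturated carbon whose other neighbour is a saturated chain carbon. The two places read the same word for word. How the core of compound 2 differs from the core of compound 3 is not broken down here; the two simply stand apart by more than one place.

Because the earlier step of a 1.1-fold lower number from compound 3 to compound 1 (0.03 log units; within the scatter) was within the scatter, the expected step of a 1.1-fold lower number from compound 2 to compound 4 (0.04 log units; within the scatter) from compound 2 to compound 4 is also small. Compound 4 is estimated at 42000 nM in this assay, expected to fall between 20000 nM and 90000 nM.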

Compound 4, solubility: 37900 nM
For compound 4 the middle estimate is 1.1-fold (0.04 log units) above the measured one; the measured number falls inside the stated range.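

On the core of compound 2, going from 2-methoxyethyl to 2-hydroxyethyl gives a 1.2-fold lower number from compound 2 to compound 4 (0.09 log units; within the scatter) in this assay and on the core of compound 3 the same change gives a 1.1-fold lower number from compound 3 to compound 1 (0.03 log units; within the scatter) so both steps lie within the scatter and the change carries over between these two cores as a step too small to tell from no change at all. For the compounds shown here, this rests on only two pairs, so it shows that the change behaved alike on these two cores but not that it would stay this small on any other core, and with both steps inside the scatter no direction of change can be read from them. The data shown offer no measured explanation of why the number stays put when this change is made.

The compounds shown carry only 2-methoxyethyl or 2-hydroxyethyl at this place, so they leave open what an amine or a carboxylic acid on the chain, or a longer chain, would do to the number. They also leave open whether the change from methoxy to hydroxy would stay this small on a core other than those of compound 2 and compound 3.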